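This account rests on a few compounds, and the source may have more. Where it says the series, first, only, none or still open, it means among the compounds named here.

Of the compounds shown here, three from one series have been measured in an assay on HEK293 cells for positive allosteric modulation of metabotropic glutamate receptor 3 (Rattus norvegicus), read by thallium flux, with a stated time of 2.5 min; a higher number here means a larger maximal response, a lower number a smaller maximal response. Compound 1 `Cc1c(OCCCCOc2ccccc2C(=O)O)ccc(C(=O)CC2CCCC2)c1C` gives 28% in this assay. Compound 2 `COC(=O)c1ccc(OCCCCOc2ccc(C(=O)CC3CCCC3)c(C)c2C)cc1` gives 24.2% in this assay. Compound 3 `Cc1c(OCCCCOc2ccccc2C(=O)O)ccc(C(=O)CC(C)C)c1C` gives 30.7% in this assay. All three values sit close together, and the steps between them stay within the usual scatter.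

Compound 2 differs from compound 1 in one place (4-(methoxycarbonyl)phenyl in place of 2-carboxyphenyl on an oxygen on a saturated carbon), and the step in this assay is a number 3.8 percentage points lower from compound 1 to compound 2 (within the scatter). Compound 3 differs from compound 1 in a different place (isopropyl in place of cyclopentyl on a saturated chain carbon bound to a carbonyl carbon), with a step in this assay of a number 2.7 percentage points higher from compound 1 to compound 3 (within the scatter). So the two cores of compound 1 and compound 3 differ only in that exchange of cyclopentyl for isopropyl.

Compound 4 `COC(=O)c1ccc(OCCCCOc2ccc(C(=O)CC(C)C)c(C)c2C)cc1` has not yet been measured. It differs from compound 3 by 4-(methoxycarbonyl)phenyl in place of 2-carboxyphenyl on an oxygen on a saturated carbon; the place is described in the same words as for the change from compound 1 to compound 2, so this is the same change made on the other core. Since the earlier step was a number 3.8 percentage points lower from compound 1 to compound 2 (within the scatter) and stayed within the scatter, a step of similar size, a number 3.7 percentage points lower from compound 3 to compound 4 (within the scatter), is expected from compound 3 to compound 4 in this assay. Compound 4 is therefore estimated to reach 27% in this assay, most likely between 17% and 37%.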

Compound 4, largest response reached (reported as percent of maximum), in percent of the reference or control that the assay uses: 27.3%
Beside the measured number, compound 4's estimate is 0.3 percentage points below it, within the range that was stated.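

In this assay, for the compounds shown here, the exchange of 2-carboxyphenyl for 4-(methoxycarbonyl)phenyl gives a number 3.4 percentage points lower from compound 3 to compound 4 (within the scatter), and this step agrees with the one seen for the same change on the other core: the same change on two cores in this assay, a number 3.8 percentage points lower (within the scatter) from compound 1 to compound 2 and a number 3.4 percentage points lower (within the scatter) from compound 3 to compound 4, 0.4 percentage points apart, within the scatter of two such steps The exchange of cyclopentyl for isopropyl, read on the two compounds that carry the ester, gives a number 3.1 percentage points higher from compound 2 to compound 4 (within the scatter), and it agrees in the same way: the same change on two cores in this assay, a number 2.7 percentage points higher (within the scatter) from compound 1 to compound 3 and a number 3.1 percentage points higher (within the scatter) from compound 2 to compound 4, 0.4 percentage points apart, within the scatter of two such steps So within these four compounds, each change behaves alike on both cores, but every step lies within the scatter, which shows only that neither change moved the maximal response measurably on these two cores, not that a real effect of either group carries over from one core to another.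

The exchange on the oxygen turns the acid into an ester and also alters the group's place on the ring in a single step, so the compounds shown cannot separate those two features. Also open, from the compounds shown here alone, is whether an amide in that group, or a tert-butyl group in place of isopropyl, would give a step beyond the scatter, and whether such a step would then carry over between cores.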